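Methyl on the Amide Nitrogen: One Change, Two Settings

This account rests on a few compounds, and the source may have more. Where it says the series, first, only, none or still open, it means among the compounds named here.

Compound 1, `CCCCNc1nc(N)nc2cccc(C(=O)NC(C)C)c12`, gives 15.6 uM in an ADME assay on HEK293 cells for agonist activity at Toll-like receptor 8 (Homo sapiens), read by a luciferase reporter, with a stated time of 6 h; a higher number here means that more compound is needed for the effect, a lower number that less compound is needed.
Compound 2, `CCCCNc1nc(N)nc2cccc(C(=O)N(C)C(C)C)c12`, reaches only the limit of this assay at > 25 uM.
Compound 3, `CCCCNc1nc(N)nc2cccc(C(=O)NCc3ccccc3)c12`, gives 1.6 uM in this assay.

The three measured compounds share one core and differ only in the amide portion. Compound 3 differs from compound 1 by benzyl in place of isopropyl on an amide-type nitrogen, and that exchange gave a 9.8-fold lower number from compound 1 to compound 3 (0.99 log units; beyond the scatter). Compound 3 thus holds the lowest of the two numbers recorded, the nearest being compound 1. Against the limit-bound compound 2, the step reads an at least 15-fold lower number from compound 2 to compound 3 (1.19 log units; beyond the scatter).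

The change of interest is methyl in place of hydrogen on an amide-type nitrogen, which turned compound 1 into compound 2 and produced an at least 1.6-fold higher number from compound 1 to compound 2 (0.20 log units; that floor lies within the scatter); the value of compound 2 sits at the limit of > 25 uM in this assay, at which 1 of the 3 values shown sits, so the true size of that step is not resolved.

Compound 4, `CCCCNc1nc(N)nc2cccc(C(=O)N(C)Cc3ccccc3)c12`, is the unmeasured partner of compound 3 and differs from it by methyl in place of hydrogen on an amide-type nitrogen. The surroundings of the changed nitrogen are the same in both pairs, so this is the same change made on a different amide substituent. Since the earlier instance of it gave an at least 1.6-fold higher number from compound 1 to compound 2 (0.20 log units; that floor lies within the scatter), compound 4 is expected to need more compound than compound 3, with the step estimated as a 3.8-fold higher number from compound 3 to compound 4 (0.57 log units; beyond the scatter). Compound 4 is therefore estimated at 6 uM in this assay, within 2 uM to 25 uM.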

Compound 4, minimum effective concentration: > 25 uM
Compound 4 was reported as a limit; the forecaster's own chance of this, stated with the estimate: 25%; middle value at least 4.1-fold (0.61 log units) from the limit.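

In this assay compound 4 gives > 25 uM, which is a limit of the assay and not a number. Methyl in place of the amide hydrogen on the benzylamino amide gives an at least 15-fold higher number from compound 3 to compound 4 (1.19 log units; beyond the scatter), and the isopropylamino pair points the same way, though only as a floor that stays within the scatter: the same change on two cores in this assay, an at least 1.6-fold higher number (0.20 log units; that floor lies within the scatter) from compound 1 to compound 2 and an at least 15-fold higher number (1.19 log units; beyond the scatter) from compound 3 to compound 4; the limit leaves it open whether they differ The direction of the change therefore carries over to the benzylamino amide, but no size does; an at least 1.6-fold higher number from compound 1 to compound 4 (0.20 log units; that floor lies within the scatter) adds only another floor, and the step between compound 2 and compound 4 cannot be read, with both ends standing at the same limit: the limit of > 25 uM in this assay, at which 2 of the 4 values shown sit.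

The compounds shown leave open how far the true values of compound 2 and compound 4 lie beyond that limit, and so whether methyl costs the same on both amides. They also leave open whether the same loss would follow with an ethyl group on the amide nitrogen, or on an amide whose substituent is a longer chain or carries an amine or a carboxylic acid.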